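This account rests on a few compounds, and the source may have more. Where it says the series, first, only, none or still open, it means among the compounds named here.

Compound 1 `COc1ccc(-c2cnc3nc(N)nc(N4CCN(C(=O)Nc5ccc(C)cc5)CC4)c3n2)cc1OC`: 0.8 nM
Compound 2 `COc1ccc(-c2cnc3nc(N)nc(N4CCN(C(=O)c5ccccc5)CC4)c3n2)cc1OC`: 400 nM

Within the data shown here, in a functional assay on cells (T-cell, Homo sapiens) for inhibition (a lower number here means a stronger inhibitor, a higher number a weaker inhibitor), compound 2 gives the higher of the two numbers, with compound 1 as its only neighbour at 0.8 nM; the single measured step, a 500-fold higher number from compound 1 to compound 2 (2.70 log units; beyond the scatter), came from phenyl in place of (4-methylphenyl)amino on a carbonyl carbon. Compound 3 `COc1ccc(-c2cnc3nc(N)nc(N4CCN(Cc5ccccc5F)CC4)c3n2)cc1OC` differs from compound 2 by 2-fluorobenzyl in place of benzoyl on an amine nitrogen in a ring. This change also sits on the amine nitrogen in the ring, but it removes the carbonyl instead of altering what hangs on it, so the measured step shows only that this position can move the number strongly, not in which direction. For compound 3 the expected value is 300 nM (range 40 nM to 2500 nM), an expected step of a 1.3-fold lower number from compound 2 to compound 3 (0.12 log units; within the scatter).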

Compound 3, half-maximal inhibitory concentration: 700 nM
Estimate against measurement, compound 3: 2.3-fold (0.37 log units) below, and the stated range covers the measured number.
By their numbers in this assay, from the lowest: compound 1; then compounds 2 and 3 (each within the scatter of the next).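

In this assay, the step from benzoyl to 2-fluorobenzyl on the ring amine nitrogen, a 1.8-fold higher number from compound 2 to compound 3 (0.24 log units; within the scatter), lies within the scatter, so keeping or losing this carbonyl makes no readable difference between these two groups. Neither group comes close to the (4-methylphenyl)carbamoyl group, as an 880-fold higher number from compound 1 to compound 3 (2.94 log units; beyond the scatter) shows. Nothing available explains this result. Still open, from the compounds shown here alone, is which part of that carbamoyl group matters. A phenylcarbamoyl group without the methyl, or a cyclohexylcarbamoyl group, would help to separate the contributions of the amide hydrogen and the aromatic ring.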